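The compounds below may be only part of what the source reports. "The series", "measured", "known", "first", "only" and "open" are said of these compounds alone.

In a physicochemical assay for solubility, using the shake flask method, in simulated intestinal fluid, measured as kinetic solubility, with a stated time of 20 h, at pH 6.5 (on this read-out higher numbers stand for higher solubility and lower numbers for lower solubility), compound 1 (`Fc1ccc(-c2nc3cnc(Nc4ccccn4)cc3[nH]2)cc1C(F)(F)F`) gives >= 50000 nM, which is a limit of the assay and not a number. Compound 2 (`Fc1ccc(Nc2cc3[nH]c(-c4cccc(C(F)(F)F)c4)nc3cn2)nc1`) gives >= 50000 nM, again a limit. Compound 3 (`Fc1ccc(Nc2cc3[nH]c(-c4ccc(F)c(F)c4)nc3cn2)nc1`) gives >= 50000 nM, so it too stands only at a limit. Compound 4 (`Fc1ccc(Nc2cc3[nH]c(-c4ccc(F)c(C(F)(F)F)c4)nc3cn2)nc1`) differs from compound 3 by trifluoromethyl in place of fluoro on an aromatic carbon, ortho to a fluoro group and meta to a large group: trifluoromethyl in place of fluoro on an aromatic carbon. Compound 1 and compound 2 also carry trifluoromethyl, and the evidence so far is the limit of >= 50000 nM in this assay, at which 3 of the 3 values shown sit. The estimated change is a number no higher from compound 3 to compound 4 (the limit leaves the size open), and nothing beyond the scatter is expected. Compound 4 is estimated at 50000 nM, with an expected range of 20000 nM to 50000 nM.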

Compound 4, solubility: >= 50000 nM
Compound 4: a limit, no number; the forecaster's own chance of this, stated with the estimate: 75%; the middle value lies on the limit itself.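

No step can be read between compound 4 and compound 1, compound 2 or compound 3, since each stands only at a limit: the limit of >= 50000 nM in this assay, at which 4 of the 4 values shown sit. The compounds shown leave open how far any of them lies past that limit, and so whether trifluoromethyl in place of fluoro changes the read-out at all.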